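A few compounds are considered here, and "the series" means these few. Any claim that something is new, unique, unknown or untested is made for them only; others in the source may bear on it.

Measured so far:
compound 1, `Cc1cc(-n2cc(C(=O)Nc3cc(F)cc(F)c3)c(=O)c3ccc(N(C)C)nc32)ccc1OCCCCCCC[N+]12CCN(CC1)CC2`: 10.6%
compound 2, `Cc1cc(-n2cc(C(=O)Nc3cc(F)cc(F)c3)c(=O)c3ccc(N(C)C)nc32)ccc1OCCCCCCC[N+]1(C)CCCCC1`: 33%

In an assay on LX2 cells for inhibition of COL1A1 promoter (Homo sapiens), read by a luciferase reporter, with a stated time of 24 h, tested at 20 uM (on this read-out lower numbers stand for a weaker effect and higher numbers for a stronger effect at the one concentration tested), compound 1 gives 10.6%, and compound 2 gives 33%, the higher of the two numbers; the step of a number 22.4 percentage points higher from compound 1 to compound 2 (beyond the scatter) lies beyond the scatter. Compound 3, `Cc1cc(-n2cc(C(=O)Nc3cc(F)cc(F)c3)c(=O)c3ccc(N(C)C)nc32)ccc1OCCCCCCC[n+]1ccccc1`, is still to be measured in this assay. Against compound 2 it carries a group of 6 heavy atoms (5 carbon, 1 nitrogen; one six-membered aromatic ring with 1 hetero atom) in place of a group of 7 heavy atoms (6 carbon, 1 nitrogen; one six-membered non-aromatic ring with 1 hetero atom), on a saturated chain carbon, seven bonds along the chain from an oxygen on an aromatic ring.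

Among the compounds with values here, only one measured step exists at this chain position, a number 22.4 percentage points higher from compound 1 to compound 2 (beyond the scatter), and it concerns a different exchange: a group with one six-membered non-aromatic ring in place of a group with two such rings. Within the data shown here, no measured step shows an aromatic ring entering at that carbon, so that one step bears on the present change only loosely. With the ring count and the net charge kept, the expected step is a number 3 percentage points lower from compound 2 to compound 3 (within the scatter), not beyond the scatter in either direction. Compound 3 is accordingly estimated at 30%, with a range from 12% to 50%.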

Compound 3, a percentage reported as inhibition, at one concentration (the size of the read-out at that concentration, not a potency): "not active" (no number reported)
Compound 3 has no reported number here; the estimate stays without a comparison.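

In this assay, within the data shown here, compound 3 is reported as not active, with no number, so no step from compound 2 to compound 3 can be read. Nothing shown bears on the reason for this result. The compounds shown leave open how large the effect of exchanging the non-aromatic ring for the aromatic ring is.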